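Stereo-defined analogue of compound 1: cytotoxicity outlook

The source may hold more compounds than are shown below. What is called first, only, known or untested is meant among the compounds shown, and "the series" means these compounds.

Working notes on the series. Compound 1 `Cc1c(Cc2ccc(OC(F)(F)F)cc2)c(=O)oc2cc(OCC(O)CN3CCC(C(N)=O)CC3)ccc12` is measured in an ADME assay on A549 cells (Homo sapiens) for cytotoxicity, read by CellTiter-Glo (on this read-out lower numbers stand for higher toxicity in this test and higher numbers for lower toxicity in this test), at 68200 nM. Among the numbers shown it stands highest of the two: compound 3 `Cc1c(Cc2ccc(-c3ccc(C#N)c(F)c3)cc2)c(=O)oc2cc(OCC(O)CN3CCC(C(N)=O)CC3)ccc12` gives 29100 nM, a step of a 2.3-fold lower number from compound 1 to compound 3 (0.37 log units; beyond the scatter). Compound 2 `COC(=O)c1ccc(Cc2c(C)c3ccc(OCC(O)CN4CCC(C(N)=O)CC4)cc3oc2=O)cc1` reaches only a limit of the assay, > 100000 nM. That limit is the limit of > 100000 nM in this assay, at which 1 of the 3 values shown sits. Against compound 2 the step of an at least 1.4-fold higher number from compound 1 to compound 2 (0.16 log units; that floor lies within the scatter) stays within the scatter, whereas an at least 3.4-fold lower number from compound 2 to compound 3 (0.53 log units; beyond the scatter) lies beyond it.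

Compound 4 `Cc1c(Cc2ccc(OC(F)(F)F)cc2)c(=O)oc2cc(OC[C@@H](O)CN3CCC(C(N)=O)CC3)ccc12` is not yet measured. It differs from compound 1 in one respect only: the two compounds have the same atoms and bonds; at least one stereo element is drawn with a configuration in one of them and without one in the other: 1 of 1 stereo elements differ; a stereocentre at a saturated chain carbon is drawn without a configuration in compound 1 and S in compound 4. Every measured step in the set exchanges a group on an aromatic carbon; none of an at least 1.4-fold higher number from compound 1 to compound 2 (0.16 log units; that floor lies within the scatter), a 2.3-fold lower number from compound 1 to compound 3 (0.37 log units; beyond the scatter) or an at least 3.4-fold lower number from compound 2 to compound 3 (0.53 log units; beyond the scatter) touches a stereocentre. Among the compounds with values here, the change from compound 1 to compound 4 has no measured counterpart, and no step beyond the scatter is expected in this assay in either direction.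

For compound 4 in this assay the expected value is 68000 nM, estimated between 30000 nM and 150000 nM. The expected step is a 1.0-fold lower number from compound 1 to compound 4 (0.00 log units; within the scatter).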

Compound 4, half-maximal cytotoxic concentration: 64900 nM
Compound 4: middle estimate off by 1.0-fold (0.02 log units), on the high side; low and high end bracket the measured number.
By their numbers in this assay, from the lowest: compound 3; then compounds 4 and 1 (each within the scatter of the next). At a limit, above all of these: compound 2.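

In this assay the series now holds a step at a stereocentre at a saturated chain carbon rather than on an aromatic carbon, and a 1.1-fold lower number from compound 1 to compound 4 (0.02 log units; within the scatter) stays within the scatter. Among the aromatic exchanges, a 2.3-fold lower number from compound 1 to compound 3 (0.37 log units; beyond the scatter) lies beyond the scatter, whereas drawing this stereocentre as S gives no separation from compound 1 on this read-out. How much this says about configuration is bounded by one fact: the fact that one of compounds 1 and 4 is drawn with a defined configuration and the other without, at the place where they differ.

As far as these compounds go, the opposite configuration at this stereocentre stays open, as does whether the S form would stay level with the undefined drawing when trifluoromethoxy is exchanged for 4-cyano-3-fluorophenyl, the exchange that separates compound 3 from compound 1. Also open, from the compounds shown here alone, is how a carboxylic acid or an amine in place of trifluoromethoxy on the aromatic carbon would read in this assay with the S configuration held.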